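A few compounds are considered here, and "the series" means these few. Any claim that something is new, unique, unknown or untested is made for them only; others in the source may bear on it.

Measured compounds:
compound 1, `C=C1C(=O)OC(C)CC1c1ccc(Br)cc1`, 1750 nM
compound 2, `C=C1C(=O)OC(C)CC1c1ccc(OC)cc1`, 800 nM
compound 3, `C=C1C(=O)O[C@H](C)[C@@H]1c1ccc(Br)cc1`, 7800 nM

Working notes on the series. In a functional assay on L1210 cells (Mus musculus) for cytotoxicity, read by MTT assay, with a stated time of 48 h (on this read-out lower numbers stand for stronger inhibition and higher numbers for weaker inhibition), compound 1 gives 1750 nM, and compound 2, which carries methoxy in place of bromo on an aromatic carbon, gives 800 nM. The change gives a 2.2-fold lower number from compound 1 to compound 2 (0.34 log units; beyond the scatter). Compound 3 shares the aromatic bromo substituent with compound 1 but differs from it in the core; the difference between the two cores is not broken down here. In this assay compound 3 gives 7800 nM, the highest number of the three measured, with its nearest neighbour compound 1 and compound 2 furthest away.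

Compound 4, `C=C1C(=O)O[C@H](C)[C@@H]1c1ccc(OC)cc1`, is not yet measured. It carries methoxy in place of bromo on an aromatic carbon. This is the same kind of change as the one from compound 1 to compound 2, made twice among the compounds shown, though the surroundings are not identical: in compound 1 the place is para to a group of 9 heavy atoms, in compound 3 para to a group of 8 heavy atoms. Within the data shown here, the only guide to the size of this new step in this assay is the single earlier step, a 2.2-fold lower number from compound 1 to compound 2 (0.34 log units; beyond the scatter). The expected step is therefore a 2.2-fold lower number from compound 3 to compound 4 (0.35 log units; beyond the scatter), of about the same size. The expectation rests on one pair only, and the two cores differ, so the band is kept wide. Compound 4 is therefore expected to give about 3500 nM, with a range from 1500 nM to 8000 nM.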

Compound 4, half-maximal inhibitory concentration: 4400 nM
Beside the measured number, compound 4's estimate is 1.3-fold (0.10 log units) below it, within the range that was stated.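

In this assay, putting methoxy in place of bromo on the core of compound 3 gives a small step in the same direction as on the core of compound 1 (a 1.8-fold lower number from compound 3 to compound 4 (0.25 log units; within the scatter)), although this step taken alone does not clear the usual scatter of repeated measurements. Set beside the earlier step, the new one shows no difference that the data can resolve: the same change on two cores in this assay, a 2.2-fold lower number (0.34 log units; beyond the scatter) from compound 1 to compound 2 and a 1.8-fold lower number (0.25 log units; within the scatter) from compound 3 to compound 4, 1.2-fold (0.09 log units) apart, within the scatter of two such steps. This supports treating the exchange of bromo for methoxy as carrying over between these two cores with about the same modest size, so the step seems to hold whichever of the two cores bears it; it does not show that the same holds on any further core or for any other exchange, it rests on two pairs in a single cell assay, and it says nothing on why the step has this size.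

On these data alone, what an amine, a carboxylic acid or a longer chain on the same aromatic carbon would give in this assay stays open, as does whether such groups would also carry from one core to the other. Also open is which part of the difference between the two cores accounts for the gap between them, as the compounds shown change those cores only as a whole.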